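The compounds below may be only part of what the source reports. "The series", "measured", "known", "first", "only" and "open" are said of these compounds alone.

In a functional assay on SGC-7901 cells (Homo sapiens) for antiproliferative activity, read by MTT assay, with a stated time of 72 h (a lower number here means a stronger inhibitor, a higher number a weaker inhibitor), compound 2 `Cc1nn(C)c(Oc2ccc(Cl)cc2)c1/C=N\OCc1c(Cl)c(-c2ccc(Cl)cc2)nn1C` gives 7510 nM. Within the data shown here, that is the lowest of the two numbers measured so far, but only by a hair: the other measured compound, compound 1 `Cc1nn(C)c(Oc2ccc(Cl)cc2)c1/C=N\OCc1c(Cl)c(-c2ccc(F)cc2)nn1C`, gives 8110 nM in this assay, and the step of a 1.1-fold lower number from compound 1 to compound 2 (0.03 log units; within the scatter) is too small to separate the two. Compound 3 `Cc1nn(C)c(Oc2ccc(OC(F)(F)F)cc2)c1/C=N\OCc1c(Cl)c(-c2ccc(Cl)cc2)nn1C` has not yet been measured in this assay. It differs from compound 2 by trifluoromethoxy in place of chloro on an aromatic carbon. Among the measured compounds shown here, the only measured step concerns the fluoro-to-chloro swap on the other aryl ring and lies within the scatter, so it offers no direct guide to what a trifluoromethoxy group does on the phenoxy ring; nothing else is known about changes at that position. For the measured compounds named here, with that single, flat comparison as the only precedent, the expected step is a 1.0-fold lower number from compound 2 to compound 3 (0.00 log units; within the scatter), that is, no shift beyond the scatter in either direction. Compound 3 is therefore estimated at 7500 nM in this assay, with a range from 2500 nM to 22000 nM to allow for the untested change.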

Compound 3, half-maximal inhibitory concentration: 3220 nM
Compound 3: middle estimate off by 2.3-fold (0.37 log units), on the high side; the range from low to high includes it.
By their numbers in this assay, from the lowest: compound 3; then compounds 2 and 1 (each within the scatter of the next).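

The phenoxy ring is a place where a single change moves the number: in this assay, trifluoromethoxy in place of chloro gives a 2.3-fold lower number from compound 2 to compound 3 (0.37 log units; beyond the scatter), a modest step, but one beyond the scatter. The earlier change on the other aryl ring, a 1.1-fold lower number from compound 1 to compound 2 (0.03 log units; within the scatter), stayed within the scatter, so it gave no sign that the series could respond to a substituent change at all. Nothing in the data shown explains the shift at the phenoxy ring.

With only chloro and trifluoromethoxy shown at this spot, it remains open whether other groups there, such as a methyl, a methoxy, an amine or a carboxylic acid, would bring the number lower still or send it back up. On these data alone, it is also open whether trifluoromethoxy would give a similar step when the other aryl ring carries fluoro instead of chloro, as it does in compound 1, or whether this step depends on that partner.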